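Trimming the pyrazolylamino Group from a Potent Kinase Binder

The source may report more compounds than this note shows. Statements on the series, on what has been measured and on what is new or still open speak of the compounds shown alone.

Compound 1 `C[C@@H]1CCCN1c1c(C#N)c2c(N)nc(Nc3cn[nH]c3)nc2n1C`: 0.4 nM
Compound 2 `Cn1c(N2CCCC2)c(C#N)c2c(N)ncnc21`: 125 nM

In an assay on isolated protein for binding affinity to Leucine-rich repeat serine/threonine-protein kinase 2 variant G2019S (Homo sapiens), read by TR-FRET and LanthaScreen, with a stated time of 2 h (on this read-out lower numbers stand for stronger inhibition and higher numbers for weaker inhibition), compound 1 gives 0.4 nM, the lowest of the two numbers. Compound 2 gives 125 nM, a gap beyond the usual scatter. Compound 3 `C[C@@H]1CCCN1c1c(C#N)c2c(N)nc(N)nc2n1C` differs from compound 1 by hydrogen in place of 1H-pyrazol-4-yl on a nitrogen on an aromatic ring. Among the compounds with values here, no measured pair isolates this change, so its size is uncertain. Compound 2 serves as a weaker reference because of its value of 125 nM, and compound 3 is expected to sit between the two, with a step of a 38-fold higher number from compound 1 to compound 3 (1.57 log units; beyond the scatter) toward weaker binding that goes beyond the scatter. Compound 3 is estimated at 15 nM, within 3 nM to 80 nM.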

Compound 3, inhibition constant: 13 nM
Compound 3: the middle estimate sits 1.2-fold (0.06 log units) above what was measured, and the stated range covers the measured number.
By their numbers in this assay, from the lowest: compound 1; then compound 3; then compound 2.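

In this assay, replacing the 1H-pyrazol-4-yl on this nitrogen with hydrogen, which turns (1H-pyrazol-4-yl)amino into amino, gives a 33-fold higher number from compound 1 to compound 3 (1.51 log units; beyond the scatter), a large step toward weaker binding and the first direct measure of this change. Even so, compound 3 gives 13 nM with only the amino group at this position, so the 1H-pyrazol-4-yl is not needed for measurable binding. Nothing available explains the size of this step. The compounds shown leave open whether another group on this nitrogen, such as methyl or phenyl, would recover any of the lost binding.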